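Trading Two Methyls for Two Chlorines on the Aryl Ring

This account rests on a few compounds, and the source may have more. Where it says the series, first, only, none or still open, it means among the compounds named here.

Compound 1, `Cc1cccc(N2CCN(CCCNc3nc(NCc4ccco4)c4ccccc4n3)CC2)c1C`: 94%
Compound 2, `CN(C)CCNc1nc(NCc2ccco2)c2ccccc2n1`: 21.7%
Compound 3, `Cc1cccc(N2CCN(CCCNc3nc(NCc4ccco4)c4cc(F)ccc4n3)CC2)c1C`: 96.7%

In a functional assay on HT-29 cells (Homo sapiens) for cytotoxicity, read by MTT assay, with a stated time of 2 days, tested at 10 uM (on this read-out lower numbers stand for less inhibition and higher numbers for more inhibition at the one concentration tested (going by the name of the read-out)), compound 1 stands second highest of the three numbers. Its nearest neighbour is compound 3, reached by a number 2.7 percentage points higher from compound 1 to compound 3 (within the scatter), so the two cannot be told apart. Among the measured compounds shown here, compound 2 gives 21.7%, the lowest of the set and beyond the scatter of compound 1; no single step links the two, so only their two values can be compared.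

The unmeasured compound 4, `Clc1cccc(N2CCN(CCCNc3nc(NCc4ccco4)c4ccccc4n3)CC2)c1Cl`, differs from compound 1 in one place: 2,3-dichlorophenyl in place of 2,3-dimethylphenyl on an amine nitrogen in a ring. For the measured compounds named here, none of the measured steps touches this group. Going by the values given here, the only single-place step known, that from compound 1 to compound 3, changes an aromatic carbon elsewhere and lies within the scatter; it offers no guide to what a new aryl group on the ring nitrogen does. The data therefore give no reason to expect a move beyond the scatter in this assay, and the estimate stays close to the value of compound 1.

Compound 4 is expected to give 92%, with a range from 75% to 99%. That estimate means an expected step of a number 2 percentage points lower from compound 1 to compound 4 (within the scatter), judged to remain within the scatter.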

Compound 4, a percentage reported as inhibition, at one concentration (the size of the read-out at that concentration, not a potency): 94.1%
For compound 4 the middle estimate is 2.1 percentage points below the measured one; low and high end bracket the measured number.
By their numbers in this assay, from the lowest: compound 2; then compounds 1, 4 and 3 (each within the scatter of the next).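

In this assay, the exchange of 2,3-dimethylphenyl for 2,3-dichlorophenyl on the amine nitrogen in the ring gives a number 0.1 percentage points higher from compound 1 to compound 4 (within the scatter), so the two compounds cannot be told apart. This is the first step shown at this position, and it shows that two chlorine atoms can take the place of two methyl groups on the aromatic ring without a difference that this read-out can resolve, though a read-out at one concentration is not a potency and leaves any difference at lower concentrations unseen. Nothing measured here explains why the two groups give matching results.

The compounds shown leave open how a plain phenyl, a pyridyl or a cyclohexyl group would behave on this ring nitrogen, since both groups tested so far are 2,3-disubstituted phenyl rings. They also leave open whether the match between 2,3-dichlorophenyl and 2,3-dimethylphenyl would persist with a longer chain between the six-membered non-aromatic ring and the shared core, or with a fluoro group on that core.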